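Chloro to Amino on a Purine Core: Expected Cytotoxicity

A few compounds are considered here, and "the series" means these few. Any claim that something is new, unique, unknown or untested is made for them only; others in the source may bear on it.

Measured compounds:
compound 1 `Nc1nc(Cl)c2ncn(Cc3ccc(CCl)cc3)c2n1` gives 74100 nM
compound 2 `ClCc1cccc(Cn2cnc3c(Cl)nc(Cl)nc32)c1` gives 10000 nM
compound 3 `ClCc1ccc(Cn2cnc3c(Cl)nc(Cl)nc32)cc1` gives 95500 nM

Of the compounds shown here, three have been tested in a functional assay on SK-MEL-2 cells (Homo sapiens) for cytotoxicity, read by sulforhodamine B assay, with a stated time of 48 h (on this read-out lower numbers stand for higher toxicity in this test and higher numbers for lower toxicity in this test), and a fourth, compound 4 `Nc1nc(Cl)c2ncn(Cc3cccc(CCl)c3)c2n1`, has not yet been measured. Compound 2 gives the lowest number of the three; its steps to compound 1 and to compound 3 both lie beyond the scatter. Compound 2 and compound 3 are built from the same atoms joined differently, and the difference between the two cores is not broken down here.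

The change from compound 3 to compound 1 is amino in place of chloro on an aromatic carbon. It made a step of a 1.3-fold lower number from compound 3 to compound 1 (0.11 log units; within the scatter), so that pair shows no real movement in this assay.

The same change is now applied to compound 2 to give compound 4: amino in place of chloro on an aromatic carbon. The place line of this change matches the earlier one word for word, so it is the same change on a core that differs only in how the same atoms are joined.

Among the compounds with values here, since the one observed instance of this change left the number essentially unmoved, compound 4 is expected to stay close to compound 2, with an estimated step of a 1.1-fold lower number from compound 2 to compound 4 (0.05 log units; within the scatter). Within the data shown here, on that basis compound 4 is estimated at 9000 nM in this assay, with a likely range from 4000 nM to 25000 nM; the range is kept wide because only one example of the change, from compound 3 to compound 1, supports it.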

Compound 4, concentration lethal to 50% of the cells: > 100000 nM
Compound 4: a limit, no number; the forecaster's own chance of this, stated with the estimate: 5%; middle value at least 11-fold (1.04 log units) away from the limit.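

In this assay compound 4 gives > 100000 nM, which is a limit of the assay and not a number. Amino in place of chloro on an aromatic carbon produced an at least 10-fold higher number from compound 2 to compound 4 (1.00 log units; beyond the scatter), so the same change did not behave alike on the two cores: the same change on two cores in this assay, a 1.3-fold lower number (0.11 log units; within the scatter) from compound 3 to compound 1 and an at least 10-fold higher number (1.00 log units; beyond the scatter) from compound 2 to compound 4, at least 12-fold (1.11 log units) apart, beyond the scatter of two such steps This shows that, within these two pairs, the result seen on one core could not be carried over to the other, but it does not show why the two cores part ways, how large the step on the core of compound 2 really is, or how the change would behave on any further core.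

The compounds shown carry only chloro or amino at this place, so it remains open how a methoxy group or a methylamino group there would read on either core. All four compounds also keep the chloromethyl group, which leaves open whether the split between the two cores would persist with a hydroxymethyl group or a plain methyl group in its place.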